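Chloro in Place of Fluoro on an Aromatic Carbon

The source may report more compounds than this note shows. Statements on the series, on what has been measured and on what is new or still open speak of the compounds shown alone.

In a functional assay on the whole organism (strain Kunming) with Mus musculus as the target, with a stated time of 0.5 h (on this read-out lower numbers stand for an effect already at smaller amounts and higher numbers for an effect only at larger amounts of compound), compound 3 (`COc1cc(OC)c(OC)cc1/C=C/COC(=O)/C=C/c1ccc(F)cc1`) gives 34.6 mg/kg and stands within the scatter of the other two measured compounds: compound 1 (`COc1cc(OC)c(OC)cc1/C=C/COC(=O)/C=C/c1ccc(OC)c(OC)c1`) at 58.1 mg/kg and compound 2 (`COc1cc(OC)c(OC)cc1/C=C/COC(=O)/C=C/c1ccc(Br)cc1`) at 61.8 mg/kg on the same read-out. The move to compound 4 (`COc1cc(OC)c(OC)cc1/C=C/COC(=O)/C=C/c1ccc(Cl)cc1`) is chloro in place of fluoro on an aromatic carbon and puts chloro in place of fluoro on an aromatic carbon para to a large group. The closest measured step is a 1.8-fold lower number from compound 2 to compound 3 (0.25 log units; within the scatter) for fluoro in place of bromo on an aromatic carbon. It lies within the scatter, as does a 1.7-fold lower number from compound 1 to compound 3 (0.23 log units; within the scatter) for 4-fluorophenyl in place of 3,4-dimethoxyphenyl. No step beyond the scatter is therefore expected in this assay here. The expected move is a 1.3-fold higher number from compound 3 to compound 4 (0.11 log units; within the scatter) and no more. Compound 4 is estimated at 45 mg/kg with an expected range from 25 mg/kg to 80 mg/kg in this read-out.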

Compound 4, dose for half-maximal effect: 53.4 mg/kg
For compound 4 the middle estimate is 1.2-fold (0.07 log units) below the measured one; measured number inside the range.
By their numbers in this assay, from the lowest: compounds 3, 4, 1 and 2 (each within the scatter of the next).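

At this aromatic carbon para to a large group, this assay shows a 1.5-fold higher number from compound 3 to compound 4 (0.19 log units; within the scatter) for chloro in place of fluoro and a 1.2-fold lower number from compound 2 to compound 4 (0.06 log units; within the scatter) for chloro in place of bromo, so fluoro, chloro and bromo all stay within the scatter of one another. The 4-chlorophenyl group likewise shows a 1.1-fold lower number from compound 1 to compound 4 (0.04 log units; within the scatter) against the 3,4-dimethoxyphenyl group and does not separate from it. No measurement shown here offers an explanation for these numbers.

Going by these compounds, it remains open whether an amine or a carboxylic acid at this position would move the number beyond the scatter.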